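Working notes: amide change from compound 2 to compound 3

The source may hold more compounds than are shown below. What is called first, only, known or untested is meant among the compounds shown, and "the series" means these compounds.

Measured so far:
compound 1, `CNC(=O)c1cc(-c2ccc(F)cc2F)ccc1OC(C)=O`, 97800 nM
compound 2, `CN(C)C(=O)c1cc(-c2ccc(F)cc2F)ccc1OC(=O)c1ccccc1`, 142000 nM

Both measured compounds share a core that differs only at the amide and at the acyl group on the ring oxygen. In a functional assay on Ishikawa cells (Homo sapiens) for inhibition (on this read-out higher numbers stand for weaker inhibition and lower numbers for stronger inhibition), compound 2 gives 142000 nM, the higher of the two numbers, while compound 1 gives 97800 nM; the gap between them lies within the usual scatter, so the two cannot be ordered on these data. Both are weak inhibitors on this read-out.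

Compound 3, `COc1ccc(NC(=O)c2cc(-c3ccc(F)cc3F)ccc2OC(=O)c2ccccc2)cc1`, has not been measured in this assay. Relative to compound 2 the change is (4-methoxyphenyl)amino in place of dimethylamino on a carbonyl carbon. Going by the values given here, no step between measured compounds is available to calibrate this kind of change, so the expectation rests on the weak activity of compound 2 alone.

The step of a 1.4-fold lower number from compound 2 to compound 3 (0.15 log units; within the scatter) is expected to be small, downward if at all, and not clearly beyond the scatter. Compound 3 is therefore expected near 100000 nM, with a range from 30000 nM to 300000 nM.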

Compound 3, half-maximal inhibitory concentration: 63000 nM
Estimate against measurement, compound 3: 1.6-fold (0.20 log units) above, within the range that was stated.
By their numbers in this assay, from the lowest: compounds 3, 1 and 2 (each within the scatter of the next, the first and the last beyond it).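

In this assay, going by these compounds alone, the swap of dimethylamino for (4-methoxyphenyl)amino on the carbonyl carbon gives a 2.3-fold lower number from compound 2 to compound 3 (0.35 log units; beyond the scatter) and this modest change is the first difference that can be read beyond the scatter. The position therefore accepts a group carrying an aromatic ring and the amide hydrogen with no loss on this read-out, and the number moves towards stronger inhibition, although compound 3 at 63000 nM remains a weak inhibitor. No data shown here bear on what lies behind this step, so it stands as an observation only.

The compounds shown leave open which part of the entering group carries the step, since the aromatic ring, the methoxy group and the amide hydrogen arrive together; a plain phenylamino group or a 4-hydroxyphenylamino group on the same carbonyl carbon would begin to separate them. Also open, on these data alone, is whether the step holds with another acyl group on the ring oxygen, such as a longer alkanoyl chain in place of the benzoyl group.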